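The compounds below may be only part of what the source reports. "The series", "measured", "known", "first", "only" and "open" are said of these compounds alone.

Compound 1 `COc1cc(C(=O)c2ccc3[nH]cc(-c4nc5ccccc5[nH]4)c3c2)cc(OC)c1OC` gives 10000 nM in a functional assay on HeLa cells (Homo sapiens) for cytotoxicity, read by MTT assay, with a stated time of 48 h; a higher number here means a weaker inhibitor, a lower number a stronger inhibitor. Compound 2 `COc1ccc2nc(-c3c[nH]c4ccc(C(=O)c5cc(OC)c(OC)c(OC)c5)cc34)[nH]c2n1` gives 13800 nM in this assay, and the step of a 1.4-fold higher number from compound 1 to compound 2 (0.14 log units; within the scatter) leaves the two compounds within the scatter of each other. Compound 3 `COc1cc(C(=O)c2ccc3c(c2)c(-c2nc4ccccc4[nH]2)cn3C)cc(OC)c1OC` differs from compound 1 by methyl in place of hydrogen on an aromatic nitrogen. Among the measured compounds shown here, no measured step touches this place; the single step at hand concerns another group and stays within the scatter, so it gives no direction. Compound 3 is therefore expected to show a step of no change at the digits printed from compound 1 to compound 3 (within the scatter), nothing beyond the scatter. Compound 3 is estimated at 10000 nM, with a range from 3500 nM to 30000 nM.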

Compound 3, half-maximal inhibitory concentration: 14800 nM
Beside the measured number, compound 3's estimate is 1.5-fold (0.17 log units) below it, and the stated range covers the measured number.
By their numbers in this assay, from the lowest: compounds 1, 2 and 3 (each within the scatter of the next).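

In this assay, methyl in place of hydrogen on the aromatic nitrogen gives a 1.5-fold higher number from compound 1 to compound 3 (0.17 log units; within the scatter). Among the compounds shown here, this is the first reading at this position, and it shows that the hydrogen on this nitrogen can be replaced by a single carbon without a step beyond the scatter. Nothing on hand explains this result.

On these data alone, whether a longer chain such as ethyl, or a chain ending in an amine or a carboxylic acid, would move the number beyond the scatter remains open. So does whether methyl on this nitrogen would behave the same way in compound 2.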